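Thiophen-2-yl in place of 4-chlorophenyl

A few compounds are considered here, and "the series" means these few. Any claim that something is new, unique, unknown or untested is made for them only; others in the source may bear on it.

In a physicochemical assay for lipophilicity, measured as octanol-water partition (on this read-out lower numbers stand for lower lipophilicity and higher numbers for higher lipophilicity), compound 1 (`COc1ccc2c(c1)[n+]([O-])c(C#N)c(-c1ccc(F)cc1)[n+]2[O-]`) gives 1.97 and compound 2 (`COc1ccc2c(c1)[n+]([O-])c(C#N)c(-c1ccc(Cl)cc1)[n+]2[O-]`) gives 2.09 so compound 2 stands level with compound 1 within the scatter. Compound 3 (`COc1ccc2c(c1)[n+]([O-])c(C#N)c(-c1cccs1)[n+]2[O-]`) differs from compound 2 by one change (thiophen-2-yl in place of 4-chlorophenyl on an aromatic carbon) ortho to a cyano group. Among the measured compounds shown here, the only measured step is a number 0.12 log units higher from compound 1 to compound 2 (within the scatter) and this chloro-for-fluoro exchange leaves the ring in place, so it offers little guidance on size. The downward direction is expected from the structural change alone. The expected step is a number 0.49 log units lower from compound 2 to compound 3 (beyond the scatter) and this lies beyond the scatter. In this assay compound 3 is estimated at 1.6 with 1.2 to 2 as the expected range.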

Compound 3, partition coefficient: 1.11
Compound 3: middle estimate off by 0.49 log units, on the high side, outside the stated range (below it).
By their numbers in this assay, from the lowest: compound 3; then compounds 1 and 2 (each within the scatter of the next).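

At this position, ortho to a cyano group, thiophen-2-yl gives a step beyond the scatter in this assay from either halogenated ring: a number 0.98 log units lower from compound 2 to compound 3 (beyond the scatter), and a number 0.86 log units lower from compound 1 to compound 3 (beyond the scatter). Exchanging the whole aromatic ring therefore moves the number further than exchanging chloro for fluoro, which stayed within the scatter. No evidence on hand bears on the reason for this step. Still open, on these data alone, is whether the thiophen-2-yl ring itself or the loss of the halogen-bearing phenyl ring accounts for the step. Unsubstituted phenyl or furan-2-yl at this position would help separate the two.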